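Methyl for nitro on the benzylidene ring of compound 2

The source may report more compounds than this note shows. Statements on the series, on what has been measured and on what is new or still open speak of the compounds shown alone.

Compound 1, `COc1ccccc1/C=C1\CCc2cc(OC)c(OC)cc2C1=O`: > 50000 nM
Compound 2, `COc1cc2c(cc1OC)C(=O)/C(=C/c1cccc([N+](=O)[O-])c1)CC2`: 9000 nM

Two compounds share this core, each measured in a functional assay on Jurkat cells (Homo sapiens) for antiproliferative activity, read by MTT assay; a lower number here means a stronger inhibitor, a higher number a weaker inhibitor. Compound 1 reaches only the limit of the assay, > 50000 nM, and gives no number. Among the compounds with values here, compound 2 is the one compound with a number, 9000 nM, so it is the only fixed point for judging the next step. The other value, that of compound 1, is a limit of the assay, (the limit of > 50000 nM in this assay, at which 1 of the 2 values shown sits).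

Compound 3, `COc1cc2c(cc1OC)C(=O)/C(=C/c1cccc(C)c1)CC2`, is not yet measured. It differs from compound 2 in one place: methyl in place of nitro on an aromatic carbon. Within the data shown here, no measured pair with a single change is available, so the size of this step is not anchored by any comparison. Compound 3 is expected to land close to or somewhat weaker than its parent, the step from compound 2 to compound 3 being a 1.7-fold higher number from compound 2 to compound 3 (0.22 log units; within the scatter). For compound 3 an estimate of 15000 nM is made, within 3000 nM to 60000 nM.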

Compound 3, half-maximal inhibitory concentration: 17000 nM
Estimate against measurement, compound 3: 1.1-fold (0.05 log units) below, and the stated range covers the measured number.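

Nitro and methyl differ in size and in hydrogen-bond acceptors, yet exchanging them on this aromatic carbon gives a 1.9-fold higher number from compound 2 to compound 3 (0.28 log units; within the scatter), so in this assay this position accepts either group without a change beyond the scatter. The other new step, with 3-methylphenyl in place of 2-methoxyphenyl, gives an at least 2.9-fold lower number from compound 1 to compound 3 (0.46 log units; beyond the scatter), the first difference in the series that lies beyond the scatter. Compound 1 has only a limit and not a number, so that step has a lower bound and no exact size: the limit of > 50000 nM in this assay, at which 1 of the 3 values shown sits.

Going by these compounds, whether the tolerance seen with nitro and methyl extends to an amine or a carboxylic acid on this aromatic carbon remains open. So does whether the step from compound 1 reflects the change of substituent or the change of its place on the ring.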